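A few compounds are considered here, and "the series" means these few. Any claim that something is new, unique, unknown or untested is made for them only; others in the source may bear on it.

Measured compounds:
- Compound 2 `O=C1c2ccccc2C(=O)N1CCOC(=S)N(C(=O)c1cccc([N+](=O)[O-])c1)c1ccc(Cl)cc1` — 18000 nM in an ADME assay on MT4 cells (Homo sapiens) for cytotoxicity, read by MTT assay; on this read-out higher numbers stand for lower toxicity in this test and lower numbers for higher toxicity in this test
- Compound 3 `Cc1ccc(N(C(=O)c2cccc([N+](=O)[O-])c2)C(=S)OCCN2C(=O)c3ccccc3C2=O)cc1` — 100000 nM
- Compound 1 `CCCCCOc1ccc(C(=O)N(C(=S)OCCN2C(=O)c3ccccc3C2=O)c2ccc(F)cc2)cc1` — a limit of this assay, > 100000 nM

Within the data shown here, compound 2 gives the lowest of the two numbers in this assay; its nearest neighbour is compound 3, reached by a 5.6-fold higher number from compound 2 to compound 3 (0.74 log units; beyond the scatter), the only single-point step among the measured compounds. Compound 1 does not give a number at all: its result is a limit, (the limit of > 100000 nM in this assay, at which 1 of the 3 values shown sits).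

Compound 4 `O=C1c2ccccc2C(=O)N1CCOC(=S)N(C(=O)c1ccc2ccccc2c1)c1ccc(Cl)cc1` has not yet been measured. It differs from compound 2 in one place: naphthalen-2-yl in place of 3-nitrophenyl on a carbonyl carbon. Among the measured compounds shown here, the one measured step, from compound 2 to compound 3, changes a group on an aromatic carbon, not the group on the carbonyl carbon that is exchanged here, so it offers no direct guide to this change. For the measured compounds named here, with no step bearing on it, the estimate for compound 4 leans on where compound 2 itself stands and on the wide spread of values seen so far, and is expected to be a modest rise, a 2.2-fold higher number from compound 2 to compound 4 (0.35 log units; beyond the scatter), with a broad margin in either direction. Compound 4 is therefore estimated at 40000 nM, expected to fall between 10000 nM and 150000 nM.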

Compound 4, half-maximal cytotoxic concentration: 37000 nM
Beside the measured number, compound 4's estimate is 1.1-fold (0.03 log units) above it; the measured number falls inside the stated range.
By their numbers in this assay, from the lowest: compound 2; then compound 4; then compound 3.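

In this assay, exchanging 3-nitrophenyl for naphthalen-2-yl on the carbonyl carbon gives a 2.1-fold higher number from compound 2 to compound 4 (0.31 log units; beyond the scatter), so the group at this place, and not only the group on an aromatic carbon changed in the earlier step, moves the number by more than the usual scatter. The step is modest, and the direction is toward lower toxicity in this test, even though the entering group swaps a nitro-bearing ring for two aromatic rings of carbon only and carries none of the hydrogen-bond acceptors of the group it replaces. Nothing given here accounts for this step, as the numbers alone do not reveal which feature of the exchanged groups matters.

The exchange removes the nitro group and adds a second ring in one move, so the compounds shown leave open which of these two differences carries the step, a question that a plain phenyl at the same place could help to settle. Also open, as far as these compounds go, is whether a ring bearing an amine or a carboxylic acid at this place would move the number the same way, and whether the exchange would give a step of similar size with methyl in place of chloro on the other aromatic ring.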